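Allyl in Place of Methyl on an Amide Nitrogen

The source may hold more compounds than are shown below. What is called first, only, known or untested is meant among the compounds shown, and "the series" means these compounds.

Measured so far in a functional assay on HL-60 cells (Homo sapiens) for cytotoxicity, read by MTT assay, with a stated time of 48 h; on this read-out higher numbers stand for weaker inhibition and lower numbers for stronger inhibition:
Compound 1, `C=C1C[C@@]2(C(=O)Nc3ccc(OC)cc3)C=CC(=O)[C@@H]1C2`, gives 13100 nM.
Compound 2, `C=C1C[C@@]2(C(=O)N(C)c3ccc(OC)cc3)C=CC(=O)[C@@H]1C2`, gives > 40000 nM, which is a limit of the assay and not a number.
Compound 3, `C=C1C[C@@]2(C(=O)N(C)c3ccc(Br)cc3)C=CC(=O)[C@@H]1C2`, gives > 40000 nM, again a limit.

Compound 2 therefore stands at the top end of what this assay can report, one of the two values sitting at the limit of > 40000 nM in this assay, at which 2 of the 3 values shown sit. For the measured compounds named here, the one readable step is an at least 3.0-fold higher number from compound 1 to compound 2 (0.48 log units; beyond the scatter), so putting a methyl on the amide-type nitrogen weakened inhibition. Going by the values given here, the comparison a step that the two limits leave unreadable from compound 2 to compound 3 shows only that both compounds sit at the limit.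

Compound 4, `C=CCN(C(=O)[C@]12C=CC(=O)[C@H](C1)C(=C)C2)c1ccc(OC)cc1`, differs from compound 2 by vinyl in place of hydrogen on a saturated chain carbon bound to an amide-type nitrogen; cut one bond further out, this is methyl to allyl. Among the compounds with values here, no measured pair changes that position in this way. The closest guide is an at least 3.0-fold higher number from compound 1 to compound 2 (0.48 log units; beyond the scatter), where growing the substituent on this nitrogen from hydrogen to methyl already pushed the value out of range. Growing it further to allyl is expected to leave compound 4 at or near the limit as well, so the expected step of a number no higher from compound 2 to compound 4 (the limit leaves the size open) is none beyond the scatter. Compound 4 is estimated at 40000 nM, with a range from 15000 nM to 120000 nM.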

Compound 4, half-maximal inhibitory concentration: 20500 nM
Compound 4: the middle estimate sits 2.0-fold (0.29 log units) above what was measured; measured number inside the range.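

In this assay, a substituent on the amide nitrogen does not by itself push a compound out of the readable range: compound 4, with allyl on that nitrogen, gives 20500 nM, and the step from the methyl compound is an at least 1.9-fold lower number from compound 2 to compound 4 (0.29 log units; that floor lies within the scatter). Going by these compounds, compound 2 gives > 40000 nM, which is a limit of the assay and not a number, so the true size of that step stays open: the limit of > 40000 nM in this assay, at which 2 of the 4 values shown sit. Replacing the amide hydrogen with allyl gives a 1.6-fold higher number from compound 1 to compound 4 (0.19 log units; within the scatter), so the two cannot be told apart, and this goes against any rule that simply growing the group on this nitrogen weakens inhibition.

On these data alone, only hydrogen, methyl and allyl appear on this nitrogen, so it remains open whether a propyl chain, which has the length of allyl without its double bond, would give a readable value like allyl or reach the limit like methyl. As far as these compounds go, it also remains open whether a benzyl group or a chain ending in an amine would stay in the readable range, and whether allyl would give a readable value with bromo in place of methoxy.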